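Series notes: chloro in place of hydrogen on compound 3

The source may hold more compounds than are shown below. What is called first, only, known or untested is meant among the compounds shown, and "the series" means these compounds.

compound 1 `O=S(=O)(Nc1nnc(SCc2ccc(Cl)cc2)s1)c1ccccc1`: in a toxicity assay on HaCaT cells (Homo sapiens) for cytotoxicity, tested at 250 uM (on this read-out lower numbers stand for a stronger effect and higher numbers for a weaker effect at the one concentration tested), compound 1 gives 71%
compound 2 `COc1ccc(S(=O)(=O)Nc2nnc(SCc3ccc(Cl)cc3)s2)cc1`: in this assay compound 2 gives 79%
compound 3 `Cc1cc(C)c(S(=O)(=O)Nc2nnc(SCc3ccccc3)s2)c(C)c1`: in this assay compound 3 gives 52%

Compound 3 stands lowest of the three numbers, with compound 1 nearest and compound 2 furthest, both beyond the scatter. Compound 4 `Cc1cc(C)c(S(=O)(=O)Nc2nnc(SCc3ccc(Cl)cc3)s2)c(C)c1` differs from compound 3 by chloro in place of hydrogen on an aromatic carbon. Going by the values given here, no measured step covers this change. Among the compounds with values here, the only measured step, a number 8 percentage points higher from compound 1 to compound 2 (within the scatter), concerns a different group on a different ring and stayed within the scatter. Within the data shown here, compound 1 and compound 2 already carry the (4-chlorobenzyl)sulfanyl group, but no pair isolates that difference from the rest. Nothing therefore points to a step beyond the scatter in this assay. Compound 4 is expected to give 52%, between 35% and 70%. The expected step of no change at the digits printed from compound 3 to compound 4 (within the scatter) is thus estimated as none beyond the scatter.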

Compound 4, a percentage reported as activity, at one concentration (the size of the read-out at that concentration, not a potency): 66%
For compound 4 the middle estimate is 14 percentage points below the measured one, and the stated range covers the measured number.
By their numbers in this assay, from the lowest: compound 3; then compounds 4, 1 and 2 (each within the scatter of the next, the first and the last beyond it).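

In this assay, going by these compounds alone, the first measured change at this position, benzyl to 4-chlorobenzyl with 2,4,6-trimethylphenyl held on the sulfonyl sulfur, gives a number 14 percentage points higher from compound 3 to compound 4 (beyond the scatter). With 4-chlorobenzyl held, 2,4,6-trimethylphenyl in place of 4-methoxyphenyl gives a number 13 percentage points lower from compound 2 to compound 4 (beyond the scatter), while 2,4,6-trimethylphenyl in place of phenyl gives a number 5 percentage points lower from compound 1 to compound 4 (within the scatter). No measurement at hand explains these steps.

Going by these compounds, whether the chloro step carries over to compounds with phenyl or 4-methoxyphenyl on the sulfonyl sulfur stays open. So does the outcome with bromo or an amine in place of chloro.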